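Replacing chloro with hydroxy on compound 2

The compounds below may be only part of what the source reports. "The series", "measured", "known", "first", "only" and "open" are said of these compounds alone.

Compound 2 `COc1cccc(C(=O)NCc2c(C)cc(C)[nH]c2=O)c1Cl` stands lowest of the three measured compounds in a physicochemical assay for lipophilicity, at pH 7.4 (a higher number here means a more lipophilic compound, a lower number a more polar compound), with 1.2 as its reading, while compound 3 `Cc1cc(C)c(CNC(=O)c2cccc(OC(C)C)c2Cl)c(=O)[nH]1` gives 2 and compound 1 `Cc1cc(C)c(CN2CCc3c(F)cc(O[C@@H]4CCOC4)c(Cl)c3C2=O)c(=O)[nH]1` gives 2.1 in the same measurement. Compound 4 `COc1cccc(C(=O)NCc2c(C)cc(C)[nH]c2=O)c1O` differs from compound 2 in one place, with hydroxy in place of chloro on an aromatic carbon. That carbon is ortho to a large group and ortho to a methoxy group, and the counted difference is hydroxy in place of chloro on an aromatic carbon at that spot.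

Among the measured compounds shown here, the only measured step from compound 2 is a number 0.80 log units higher from compound 2 to compound 3 (beyond the scatter) and it is a modest one. It is isopropyl in place of methyl on an oxygen, so it leaves the chloro untouched and serves only as a yardstick of size. For the measured compounds named here, no measured pair exchanges chloro for hydroxy. A hydrogen-bond donor and acceptor enter where the chloro had none, so a downward step of similar modest size is expected in this assay rather than none. The estimated change is a number 0.50 log units lower from compound 2 to compound 4 (beyond the scatter) on this reading. For compound 4 the estimated value is 0.7 with an expected range from 0.2 to 1.2 in this measurement.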

Compound 4, distribution coefficient: 1.9
Estimate against measurement, compound 4: 1.20 log units below, and the stated range ends below it.
By their numbers in this assay, from the lowest: compound 2; then compounds 4, 3 and 1 (each within the scatter of the next).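

In this assay, hydroxy in place of chloro on this aromatic carbon, ortho to a large group and ortho to a methoxy group, gives a number 0.70 log units higher from compound 2 to compound 4 (beyond the scatter) and so moves the number upward, even though the entering group counts a hydrogen-bond donor and acceptor where the chloro counted none. Among the compounds shown here, the earlier step, a number 0.80 log units higher from compound 2 to compound 3 (beyond the scatter), changed only the group on the oxygen and left the chloro in place, so this is the first measured change at this carbon itself. Nothing in the available data gives a reason for the direction of this step.

The compounds shown leave open whether an amine or a carboxylic acid on this same carbon would move the number in the same direction. They also leave open whether hydroxy in place of chloro gives a similar step on the core of compound 1.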